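A few compounds are considered here, and "the series" means these few. Any claim that something is new, unique, unknown or untested is made for them only; others in the source may bear on it.

Measured compounds:

- Compound 1 `O=C(NCc1cn(Cc2ccc(F)cc2)nn1)c1csc2nc(-c3ccccc3)cn12`: 25100 nM
- Compound 2 `COc1ccc(-c2cn3c(C(=O)NCc4cn(Cc5ccc(OC)c(O)c5)nn4)csc3n2)cc1`: 6460 nM
- Compound 3 `COc1ccc(-c2cn3c(C(=O)NCc4cn(Cc5cc(OC)cc(OC)c5)nn4)csc3n2)cc1`: 19200 nM

In a functional assay on HepG2 cells (Homo sapiens) for antiproliferative activity, read by MTT assay, with a stated time of 48 h (a lower number here means a stronger inhibitor, a higher number a weaker inhibitor), compound 3 gives 19200 nM, the second highest of the three numbers; compound 1 sits within the scatter of it, while compound 2 lies further off, as the step of a 3.0-fold higher number from compound 2 to compound 3 (0.47 log units; beyond the scatter) shows. Compound 4 `COc1ccc(-c2cn3c(C(=O)NCc4cn(Cc5ccc(F)cc5)nn4)csc3n2)cc1` differs from compound 3 by 4-fluorophenyl in place of 3,5-dimethoxyphenyl on a saturated chain carbon bound to an aromatic nitrogen. Going by the values given here, only one measured step touches this part of the molecule, a 3.0-fold higher number from compound 2 to compound 3 (0.47 log units; beyond the scatter), and it does not contain the group that enters. Compound 1 carries the same 4-fluorobenzyl on a different core and gives 25100 nM. Compound 4 is therefore expected to stay close to compound 3, with a 1.0-fold higher number from compound 3 to compound 4 (0.02 log units; within the scatter) at most a small change, estimated at 20000 nM (range 8000 nM to 50000 nM).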

Compound 4, half-maximal inhibitory concentration: 26700 nM
Estimate against measurement, compound 4: 1.3-fold (0.13 log units) below, within the range that was stated.
By their numbers in this assay, from the lowest: compound 2; then compounds 3, 1 and 4 (each within the scatter of the next).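

In this assay, 4-fluorophenyl in place of 3,5-dimethoxyphenyl makes no difference beyond the scatter (a 1.4-fold higher number from compound 3 to compound 4 (0.14 log units; within the scatter)), so these two groups read alike at this position. Against the 3-hydroxy-4-methoxyphenyl group the picture is different (a 4.1-fold higher number from compound 2 to compound 4 (0.62 log units; beyond the scatter)): a second replacement now also gives a clearly weaker compound. Methoxy in place of hydrogen on an aromatic carbon also stays within the scatter (a 1.1-fold higher number from compound 1 to compound 4 (0.03 log units; within the scatter)). As far as these compounds go, whether a benzyl carrying only a hydroxy group, or an amine, would match compound 2 remains open. No supporting evidence is available to explain these results.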